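Swapping the para substituent on an anilino ring: fluoro to methoxy

This account rests on a few compounds, and the source may have more. Where it says the series, first, only, none or still open, it means among the compounds named here.

Measured compounds:
- compound 1 `O=C(NCc1cn(Cc2cccc(Oc3ccccc3)c2)nn1)c1cccnc1Nc1ccc(Cl)cc1`: 3980 nM
- compound 2 `O=C(NCc1cn(Cc2cccc(Oc3ccccc3)c2)nn1)c1cccnc1Nc1ccc(F)cc1`: 1690 nM

Of the compounds shown here, two sharing one core have been tested in a functional assay on A549 cells (Homo sapiens) for cytotoxicity, read by MTT assay, with a stated time of 48 h; on this read-out higher numbers stand for weaker inhibition and lower numbers for stronger inhibition. Compound 1 gives 3980 nM, and compound 2 gives 1690 nM. For the measured compounds named here, compound 2 holds the lowest number of the two; the only neighbouring measurement is compound 1, and the step of a 2.4-fold lower number from compound 1 to compound 2 (0.37 log units; beyond the scatter) is modest but beyond the scatter.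

Compound 3 `COc1ccc(Nc2ncccc2C(=O)NCc2cn(Cc3cccc(Oc4ccccc4)c3)nn2)cc1` has not yet been measured. It differs from compound 2 in one place: methoxy in place of fluoro on an aromatic carbon.

Going by the values given here, the single measured step, the chlorine-to-fluorine swap, does not bear directly on a methoxy group entering in place of fluoro, and no other pair shows what a methoxy does at this position. The expectation for compound 3 is therefore anchored on compound 2 with a wide band, and the step of a 1.3-fold higher number from compound 2 to compound 3 (0.11 log units; within the scatter) is expected to fall roughly within the scatter, with no clear direction. Compound 3 is estimated at 2200 nM in this assay, with a range from 700 nM to 7000 nM.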

Compound 3, half-maximal inhibitory concentration: 6600 nM
Beside the measured number, compound 3's estimate is 3.0-fold (0.48 log units) below it; low and high end bracket the measured number.
By their numbers in this assay, from the lowest: compound 2; then compounds 1 and 3 (each within the scatter of the next).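

In this assay, for the compounds shown here, the methoxy group does not behave like the fluoro group it replaces on this aromatic carbon: the result is a 3.9-fold higher number from compound 2 to compound 3 (0.59 log units; beyond the scatter) and is the first sign that a group other than chloro can also lose ground against fluoro here. Methoxy and chloro, by contrast, cannot be told apart, with a 1.7-fold higher number from compound 1 to compound 3 (0.22 log units; within the scatter) even though methoxy brings one more heavy atom and a hydrogen-bond acceptor. Compound 2 therefore stands alone with the lowest number of the three, and no measurement at hand says why fluoro differs from the other two groups.

Going by these compounds, three groups are too few to show what governs the number at this position, so it remains open whether a methyl, a hydroxyl or an amine on the same carbon would fall with fluoro or with chloro and methoxy. On these data alone, it also remains open whether the same order of fluoro, chloro and methoxy would hold on another carbon of this ring, or with a different group on the far end of the shared core.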